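Three Aryl Sulfonamides and a Fourth Awaiting Measurement

The compounds below may be only part of what the source reports. "The series", "measured", "known", "first", "only" and "open" are said of these compounds alone.

The set comprises three sulfonamides on a shared core, compound 1 `Cc1ccc(S(=O)(=O)NC(C2=CC(=O)c3c(O)ccc(O)c3C2=O)C(C)C)cc1`, compound 2 `Cc1ccccc1S(=O)(=O)NC(C1=CC(=O)c2c(O)ccc(O)c2C1=O)C(C)C` and compound 3 `COc1ccc(S(=O)(=O)NC(C2=CC(=O)c3c(O)ccc(O)c3C2=O)C(C)C)cc1`, together with the unmeasured compound 4 `CC(C)C(NS(=O)(=O)c1cccc(Br)c1)C1=CC(=O)c2c(O)ccc(O)c2C1=O`; they differ only in the aryl group on the sulfonyl sulfur. In a functional assay on HL-60 cells (Homo sapiens) for cytotoxicity, read by MTT assay (on this read-out higher numbers stand for weaker inhibition and lower numbers for stronger inhibition), compound 2 gives 190 nM. In this assay compound 1 gives "not determined" (no result reported), and compound 3 gives "not determined" (no result reported), so compound 3 stands without a number on this read-out and cannot be set against compound 2. The step from compound 3 to compound 4 is 3-bromophenyl in place of 4-methoxyphenyl on a sulfonyl sulfur. For the measured compounds named here, no step between two measured compounds is available, so the size of such a swap in this assay is unknown; the expectation is a shift of no more than the usual scatter, in either direction, with compound 2 as the only anchor. Compound 4 is expected at an estimated 250 nM, with a range from 80 nM to 800 nM. This expectation rests on compound 2 at 190 nM in this assay.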

Compound 4, half-maximal inhibitory concentration: 790 nM
Beside the measured number, compound 4's estimate is 3.2-fold (0.50 log units) below it, within the range that was stated.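

In this assay, the aryl group on the sulfonyl sulfur turns out to matter: 3-bromophenyl in place of 2-methylphenyl gives a 4.2-fold higher number from compound 2 to compound 4 (0.62 log units; beyond the scatter), so this exchange weakens inhibition on this read-out. The steps involving compound 1 and compound 3 cannot be read, which leaves this single step as the only measured size of an aryl change at this position. No measurement shown here accounts for the shift.

Since this step changes both the substituent and its place on the ring, the compounds shown leave open whether the bromine or its location sets the difference. A plain phenyl, a 2-bromophenyl or a 3-methylphenyl group on the same sulfonyl sulfur would separate those two changes, and a pyridine ring would extend the question beyond carbon-only aromatic rings.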